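The compounds below may be only part of what the source reports. "The series", "measured", "known", "first", "only" and "open" are said of these compounds alone.

Of the compounds shown here, three of one series have been measured in a functional assay on HeLa cells (Homo sapiens) for antiproliferative activity, read by XTT assay, with a stated time of 72 h; on this read-out lower numbers stand for stronger inhibition and higher numbers for weaker inhibition. Compound 1, `C=C(C)CCC[C@]1(C)C2=CCC[C@](C)(CC(=O)c3ccoc3)[C@H]2CC[C@H]1C`, is reported only as a limit, > 100000 nM, which is the limit of > 100000 nM in this assay, at which 1 of the 3 values shown sits. Compound 2, `C=C(C)CC[C@]1(C)C2=CCC[C@](C)(C[C@@H](O)c3ccoc3)[C@H]2CC[C@H]1C`, gives 30200 nM. Compound 3, `C=C(C)CC[C@]1(C)C2=CCC[C@](C)(C[C@@H](OC(C)=O)C3=CC(=O)OC3O)[C@H]2CC[C@H]1C`, gives 6700 nM, the lowest of the two numbers shown, and its gap to compound 2 lies beyond the usual scatter of repeated measurements. A further compound, compound 4, `C=C(C)CC[C@]1(C)C2=CCC[C@](C)(C[C@@H](O)C3=CC(=O)OC3O)[C@H]2CC[C@H]1C`, has not yet been measured in this assay. It differs from compound 3 in one place: hydrogen in place of acetyl on an oxygen on a saturated carbon. Within the data shown here, no two measured compounds differ by this change alone, so the size of the step cannot be read from the measured compounds. A small step is expected, if any, towards a weaker result; the expected step in this assay is a 1.5-fold higher number from compound 3 to compound 4 (0.17 log units; within the scatter), which would remain close to the scatter. Compound 4 is therefore estimated at 10000 nM, with a range from 3000 nM to 35000 nM.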

Compound 4, half-maximal inhibitory concentration: 5400 nM
The estimate for compound 4 lay 1.9-fold (0.27 log units) above the measured number; the range from low to high includes it.
By their numbers in this assay, from the lowest: compounds 4 and 3 (each within the scatter of the next); then compound 2. At a limit, above all of these: compound 1.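

In this assay, the change from acetoxy to hydroxy on an oxygen on a saturated carbon gives a step that cannot be told from the scatter: a 1.2-fold lower number from compound 3 to compound 4 (0.09 log units; within the scatter), so the acetyl group is not needed for the number seen with compound 3. With the hydroxy group in place on both sides, the ring group can now be compared in one place, and the group with the five-membered non-aromatic ring goes with the lower number, a step beyond the scatter: a 5.6-fold lower number from compound 2 to compound 4 (0.75 log units; beyond the scatter). Nothing measured here gives a reason for either step. The compounds shown leave open how an amine or a longer ester chain would read at this position on the saturated carbon. They also leave open which atoms of the non-aromatic ring group carry the step.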